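From Hydroxy to Methoxy in a Small Compound Series

The source may hold more compounds than are shown below. What is called first, only, known or untested is meant among the compounds shown, and "the series" means these compounds.

Compound 1 `COc1cc(/C=C2\Cc3c(cc(OC)c(OC)c3OC)C2=O)cc(OC)c1OC`: 2370 nM
Compound 2 `COc1ccc(/C=C2\Cc3cc(OC)c(OC)c(OC)c3C2=O)cc1`: > 10000 nM
Compound 3 `COc1cc2c(cc1O)C(=O)/C(=C/c1ccc(OC)c(OC)c1OC)C2`: 1590 nM

In a functional assay on HeLa cells (Homo sapiens) for antiproliferative activity, read by MTT assay, with a stated time of 48 h (on this read-out lower numbers stand for stronger inhibition of growth and higher numbers for weaker inhibition of growth), compound 3 gives 1590 nM, and this lies within the usual scatter of compound 1 at 2370 nM. Compound 2 gives only a limit of the assay, > 10000 nM, and not a number.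

Compound 4 `COc1cc2c(cc1OC)C(=O)/C(=C/c1ccc(OC)c(OC)c1OC)C2` is still unmeasured. It differs from compound 3 in one place: methyl in place of hydrogen on an oxygen on an aromatic ring, with methyl in place of hydrogen on an oxygen on an aromatic ring, so hydroxy becomes methoxy.

Within the data shown here, no measured pair shows this change alone, so any expectation for this assay is indirect. Compound 1, which has no hydroxy group, gives 2370 nM, so no step beyond the scatter is expected. Compound 2, also without a hydroxy group, stands at the limit > 10000 nM, so a much higher number remains possible. The expected change is a 1.3-fold higher number from compound 3 to compound 4 (0.10 log units; within the scatter). The estimated value for compound 4 is 2000 nM, with an expected range from 500 nM to 8000 nM.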

Compound 4, concentration for 50% growth inhibition: > 10000 nM
Compound 4: no number, only a limit (the forecaster's own chance of this, stated with the estimate: 15%); at least 5.0-fold (0.69 log units) between middle value and limit.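

Among these compounds, the pair of compound 3 and compound 4 is the first here to differ in one place, so it isolates this change: in this assay, going from hydroxy to methoxy on an oxygen on an aromatic ring gives an at least 6.2-fold higher number from compound 3 to compound 4 (0.79 log units; beyond the scatter). Compound 4 gives > 10000 nM, which is a limit of the assay and not a number. The hydrogen on this oxygen therefore matters for the read-out, although the full size of the step cannot be read from a limit: the limit of > 10000 nM in this assay, at which 2 of the 4 values shown sit.

An amine in place of the hydroxy, or a longer chain on the oxygen, is not among the compounds shown, so it remains open how other groups at this place would behave. As far as these compounds go, it also remains open whether the same change would have a similar effect in another compound of the series.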